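Compound 3 to compound 4: a side chain swap

The compounds below may be only part of what the source reports. "The series", "measured", "known", "first", "only" and "open" are said of these compounds alone.

- Compound 1 `Fc1cccc(Cn2ccc3nc(-c4ccccc4)nc-3c2)c1`: > 100000 nM, a limit
- Compound 2 `Fc1ccc(Cn2ccc3nc(-c4ccccc4)nc-3c2)cc1`: > 100000 nM, a limit
- Compound 3 `CCC(CC)Cn1ccc2nc(-c3ccccc3)nc-2c1`: > 100000 nM, a limit

All three compounds were tested in an ADME assay on MDBK cells (Bos taurus) for cytotoxicity; on this read-out higher numbers stand for lower toxicity in this test and lower numbers for higher toxicity in this test. Compound 3 has no exact value, only a limit, and it shares that position with the other two: the limit of > 100000 nM in this assay, at which 3 of the 3 values shown sit. Compound 4 `CC(C)=CCn1ccc2nc(-c3ccccc3)nc-2c1` carries 2-methylprop-1-en-1-yl in place of pentan-3-yl on a saturated chain carbon bound to an aromatic nitrogen. Two measured changes at this same place bear on it, a step that the two limits leave unreadable from compound 1 to compound 3 and a step that the two limits leave unreadable from compound 2 to compound 3, and neither has a readable size. A third, a step that the two limits leave unreadable from compound 1 to compound 2, is equally unreadable. No step beyond the scatter is therefore expected in this assay, and no direction can be predicted. The estimated step is a number no higher from compound 3 to compound 4 (the limit leaves the size open). For compound 4 the expected value is 100000 nM, with an estimated range of 40000 nM to 100000 nM.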

Compound 4, half-maximal cytotoxic concentration: > 100000 nM
Compound 4 gave a limit, no number (the forecaster's own chance of this, stated with the estimate: 80%); the middle value lies on the limit itself.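

Compound 4 ends at a limit, as do compound 1, compound 2 and compound 3, so no step among them can be read: the limit of > 100000 nM in this assay, at which 4 of the 4 values shown sit.

As far as these compounds go, whether these side chains differ at all in this assay stays open.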